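Amide-terminus variation on the aminopyrazolopyridine cytotoxicity series

This account rests on a few compounds, and the source may have more. Where it says the series, first, only, none or still open, it means among the compounds named here.

Compound 2 `NCCNC(=O)Cn1nc(N)c2c(C(F)(F)F)cc(-c3ccccc3)nc21` gives 50200 nM in a functional assay on A549 cells (Homo sapiens) for cytotoxicity, read by MTT assay, with a stated time of 24 h; a higher number here means a weaker inhibitor, a lower number a stronger inhibitor. Among the three measured compounds it holds the second highest number: compound 1 `NNC(=O)Cn1nc(N)c2c(C(F)(F)F)cc(-c3ccccc3)nc21` gives 53600 nM, and a 1.1-fold lower number from compound 1 to compound 2 (0.03 log units; within the scatter); compound 3 `Nc1nn(CC(=O)N2CCCCC2)c2nc(-c3ccccc3)cc(C(F)(F)F)c12` gives 1200 nM, and a 42-fold lower number from compound 2 to compound 3 (1.62 log units; beyond the scatter). Compound 4 `Nc1nn(CC(=O)NCC(=O)O)c2nc(-c3ccccc3)cc(C(F)(F)F)c12` has not been measured; it differs from compound 2 in one place: carboxy in place of aminomethyl on a saturated chain carbon bound to an amide-type nitrogen.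

Going by the values given here, no measured step covers this exchange. Among the compounds with values here, the one step that keeps the secondary amide and alters only its substituent, a 1.1-fold lower number from compound 1 to compound 2 (0.03 log units; within the scatter), stayed within the scatter, whereas the large shift, a 45-fold lower number from compound 1 to compound 3 (1.65 log units; beyond the scatter), came only with the tertiary amide of compound 3, which compound 4 does not carry. On that basis the expected step of a 1.1-fold higher number from compound 2 to compound 4 (0.04 log units; within the scatter) is none beyond the scatter, with compound 4 staying close to compound 2 in this assay. Compound 4 is therefore estimated at 55000 nM, within a range of 22000 nM to 130000 nM.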

Compound 4, half-maximal inhibitory concentration: 19900 nM
Compound 4: middle estimate off by 2.8-fold (0.44 log units), on the high side, and the stated range ends above it.
By their numbers in this assay, from the lowest: compound 3; then compound 4; then compounds 2 and 1 (each within the scatter of the next).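

Within the secondary amides, the terminus does respond in this assay after all: a 2.5-fold lower number from compound 2 to compound 4 (0.40 log units; beyond the scatter) is a modest step, and a 2.7-fold lower number from compound 1 to compound 4 (0.43 log units; beyond the scatter) is likewise modest, so replacing aminomethyl with carboxy on a saturated chain carbon bound to an amide-type nitrogen shifts the number where the earlier secondary amide step did not. The tertiary amide still stands well apart, since a 17-fold higher number from compound 3 to compound 4 (1.22 log units; beyond the scatter) is a large step, and carboxy closes only part of the distance to piperidin-1-yl.

Still open, going by these compounds, is whether a methyl ester in place of carboxy, a longer chain ending in the carboxylic acid, or a morpholin-4-yl amide in place of piperidin-1-yl would move the number further in this assay. Nothing given here bears on what lies behind the step from aminomethyl to carboxy.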